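Replacing the Ethylphenyl Sulfonyl Group with a Methoxyphenyl Group

The compounds below may be only part of what the source reports. "The series", "measured", "known", "first", "only" and "open" are said of these compounds alone.

Compound 1, `O=S(=O)(Nc1ccc(-c2nc3ccccc3o2)cc1)c1ccc(F)c(C(F)(F)F)c1`, gives 28000 nM in an assay on cells for inhibition of HSP60/HSP10 (Homo sapiens), with a stated time of 60 min; a higher number here means a weaker inhibitor, a lower number a stronger inhibitor.
Compound 2, `CCc1ccc(S(=O)(=O)Nc2ccc(-c3nc4ccccc4o3)cc2)cc1`, reaches only a limit of this assay, > 100000 nM, so no number is known for it.
Compound 3, `O=S(=O)(Nc1ccc(-c2nc3ccccc3o2)cc1)c1ccc(C(F)(F)F)cc1`, gives 50000 nM in this assay.

All three share one core carrying a sulfonamide, and they differ only in the aromatic group on the sulfonyl sulfur. Compound 2 stands at a limit, (the limit of > 100000 nM in this assay, at which 1 of the 3 values shown sits), and has no measured number of its own. Among the compounds with values here, the one measured step that starts from compound 2 is an at least 2.0-fold lower number from compound 2 to compound 3 (0.30 log units; that floor lies within the scatter), brought about by trifluoromethyl in place of ethyl on an aromatic carbon; its floor lies within the scatter, so it shows at most a modest gain.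

Compound 4, `COc1cccc(S(=O)(=O)Nc2ccc(-c3nc4ccccc4o3)cc2)c1`, differs from compound 2 by 3-methoxyphenyl in place of 4-ethylphenyl on a sulfonyl sulfur. Within the data shown here, no measured step covers this kind of change, so the expectation rests only on the observation that every variation of this group so far has left the compounds weak in this assay. The expected step is an at least 1.4-fold lower number from compound 2 to compound 4 (0.15 log units; that floor lies within the scatter), a change that is not expected to exceed the scatter. Compound 4 is therefore estimated at 70000 nM, within a range from 25000 nM to 200000 nM.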

Compound 4, half-maximal inhibitory concentration: 80000 nM
The estimate for compound 4 lay 1.1-fold (0.06 log units) below the measured number; the range from low to high includes it.
By their numbers in this assay, from the lowest: compounds 1, 3 and 4 (each within the scatter of the next, the first and the last beyond it). At a limit, above all of these: compound 2.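

Putting 3-methoxyphenyl in place of 4-ethylphenyl on a sulfonyl sulfur gives an at least 1.2-fold lower number from compound 2 to compound 4 (0.09 log units; that floor lies within the scatter), so this change is not shown to bring a gain beyond the scatter, although a larger one is not ruled out. On these data alone, the true size of the step stays unknown because compound 2 has only a limit and no number of its own: the limit of > 100000 nM in this assay, at which 1 of the 4 values shown sits. What compound 4 adds is that a group without fluorine can also give a number in this assay, since compound 3 at 50000 nM and compound 4 at 80000 nM lie within the scatter of each other.

This change alters both the group and where it sits on the ring, so 4-methoxyphenyl would be needed to tell the two effects apart. As far as these compounds go, whether an amine or a carboxylic acid on this aromatic ring would give a much lower number than those seen here also remains open.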